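Swapping 4-isopropylphenyl for 4-chloro-2-fluorophenyl

The source may report more compounds than this note shows. Statements on the series, on what has been measured and on what is new or still open speak of the compounds shown alone.

- Compound 1 `N#Cc1ccc(C(O)(c2ccc(C(F)(F)F)cc2)c2cccnc2)cc1`: 76500 nM
- Compound 2 `NC(=O)c1cccc(C(O)(c2ccc(C(F)(F)F)cc2)c2cccnc2)c1`: > 100000 nM (a limit, not a number)
- Compound 3 `CC(C)c1ccc(C(O)(c2ccc(C(F)(F)F)cc2)c2cccnc2)cc1`: 56300 nM

In an ADME assay on L6 cells (Rattus norvegicus) for cytotoxicity, read by resazurin assay, with a stated time of 72 h (on this read-out higher numbers stand for weaker inhibition and lower numbers for stronger inhibition), compound 3 gives 56300 nM, within the scatter of compound 1, as the step of a 1.4-fold lower number from compound 1 to compound 3 (0.13 log units; within the scatter) shows. The entry for compound 2 is a limit. Compound 4 `OC(c1ccc(C(F)(F)F)cc1)(c1cccnc1)c1ccc(Cl)cc1F` carries 4-chloro-2-fluorophenyl in place of 4-isopropylphenyl on a saturated chain carbon bound to two aromatic carbons and an oxygen on a saturated carbon. Two measured steps change the group at this place: a 1.4-fold lower number from compound 1 to compound 3 (0.13 log units; within the scatter) lies within the scatter, and the floor of an at least 1.7-fold lower number from compound 2 to compound 3 (0.24 log units; that floor lies within the scatter) also lies within it. Neither points to a large move, so no step beyond the scatter is expected in this assay. The expected step is a 1.1-fold lower number from compound 3 to compound 4 (0.05 log units; within the scatter). Compound 4 is estimated at 50000 nM, with an expected range of 22000 nM to 100000 nM.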

Compound 4, half-maximal inhibitory concentration: > 100000 nM
Compound 4: a limit, no number; the forecaster's own chance of this, stated with the estimate: 12%; middle value at least 2.0-fold (0.30 log units) away from the limit.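

In this assay the entry for compound 4 is a limit, not a number. Against the measured compounds the change therefore gives only floors, an at least 1.7-fold higher number from compound 3 to compound 4 (0.24 log units; that floor lies within the scatter) and an at least 1.3-fold higher number from compound 1 to compound 4 (0.11 log units; that floor lies within the scatter), so no move beyond the scatter is established, and the step between compound 2 and compound 4 cannot be read. What is new is that 4-chloro-2-fluorophenyl reaches the top of the read-out as 3-carbamoylphenyl does, which restricts what this position can show: the limit of > 100000 nM in this assay, at which 2 of the 4 values shown sit.

From the compounds shown here alone, how far compound 2 and compound 4 lie past that limit stays open. Also open, going by these compounds, is whether an amine or a carboxylic acid on the phenyl ring at this place would produce a step beyond the scatter.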